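The source may report more compounds than this note shows. Statements on the series, on what has been measured and on what is new or still open speak of the compounds shown alone.

Measured so far:
compound 1 `NC(=S)N/N=C1/C=C(Nc2ccc(Cl)cc2)C(Nc2ccc(Cl)cc2)=NC1=O`: 820 nM
compound 2 `NC(=S)N/N=C1/C=C(Nc2ccc(F)cc2)C(Nc2ccc(F)cc2)=NC1=O`: 3660 nM

In a functional assay on Bel-7402 cells (Homo sapiens) for antiproliferative activity, read by MTT assay, with a stated time of 72 h (a lower number here means a stronger inhibitor, a higher number a weaker inhibitor), compound 1 gives the lowest of the two numbers; compound 2 gives a number beyond the scatter above it. Compound 3 `N/C(=N\N=C1\C=C(Nc2ccc(Cl)cc2)C(Nc2ccc(Cl)cc2)=NC1=O)SCc1ccccc1` is not yet measured. It differs from compound 1 in a group of 11 heavy atoms (8 carbon, 2 nitrogen, 1 sulfur; one six-membered aromatic ring of carbon only) in place of a group of 4 heavy atoms (1 carbon, 2 nitrogen, 1 sulfur; no ring), on a double-bonded nitrogen. Going by the values given here, no measured pair shows a change of this kind, so neither direction nor size can be read from the data; a modest step is expected, most likely toward a weaker inhibitor, and the expected step is a 1.8-fold higher number from compound 1 to compound 3 (0.26 log units; within the scatter). Compound 3 is estimated at 1500 nM, with a range from 300 nM to 8000 nM.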

Compound 3, half-maximal inhibitory concentration: 17300 nM
For compound 3 the middle estimate is 12-fold (1.06 log units) below the measured one; the measured number lies above the stated range.
By their numbers in this assay, from the lowest: compound 1; then compound 2; then compound 3.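

In this assay, the place on the double-bonded nitrogen proves sensitive to this change: the group of 11 heavy atoms, with its six-membered aromatic ring of carbon only, gives a 21-fold higher number from compound 1 to compound 3 (1.32 log units; beyond the scatter) and leaves compound 3 as the weakest of the three. Going by these compounds alone, this is the first step read at this place, and it runs toward a weaker inhibitor. No available measurement accounts for the size of this step.

On these data alone, whether the aromatic ring alone carries the step stays open. Also open, as far as these compounds go, is whether a methyl group, a longer chain or a carboxylic acid in the entering group would bring the number back toward compound 1.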